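Thioether variation on the shared core: difluorobenzyl step

The compounds below may be only part of what the source reports. "The series", "measured", "known", "first", "only" and "open" are said of these compounds alone.

Compound 2 `CCCSc1nnc(COc2cc(C)c3c(C)cc(=O)oc3c2)o1` carries a propylsulfanyl group on the shared core. In a functional assay on MDA-MB-231 cells (Homo sapiens) for antiproliferative activity, read by MTT assay, with a stated time of 24 h (a lower number here means a stronger inhibitor, a higher number a weaker inhibitor), compound 2 reaches only a limit, > 100000 nM. Compound 1 `CCSc1nnc(COc2cc(C)c3c(C)cc(=O)oc3c2)o1` likewise gives only a limit, > 100000 nM. Compound 3 `CCCCCSc1nnc(COc2cc(C)c3c(C)cc(=O)oc3c2)o1` also stays at a limit, > 100000 nM. The steps a step that the two limits leave unreadable from compound 1 to compound 2, a step that the two limits leave unreadable from compound 1 to compound 3 and a step that the two limits leave unreadable from compound 2 to compound 3 are unreadable because of the limit of > 100000 nM in this assay, at which 3 of the 3 values shown sit. Compound 4 `Cc1cc(OCc2nnc(SCc3ccc(F)c(F)c3)o2)cc2oc(=O)cc(C)c12` differs from compound 2 by 3,4-difluorophenyl in place of ethyl on a saturated chain carbon bound to a sulfur. Among the compounds with values here, none of the measured steps offers a readable size for this change, so no direction can be taken from them. The value of compound 4 is expected near a limit, estimated at 80000 nM with a range from 15000 nM to 400000 nM. The step from compound 2 to compound 4 is accordingly expected to be an at least 1.2-fold lower number from compound 2 to compound 4 (0.09 log units; that floor lies within the scatter).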

Compound 4, half-maximal inhibitory concentration: > 100000 nM
Compound 4: a limit, no number; the forecaster's own chance of this, stated with the estimate: 60%; at least 1.2-fold (0.09 log units) between middle value and limit.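

Compound 4 also stays at a limit, > 100000 nM, so its steps to compound 1, compound 2 and compound 3 cannot be read: the limit of > 100000 nM in this assay, at which 4 of the 4 values shown sit.

The compounds shown leave open whether any group on the sulfur of the shared core gives a number rather than a limit in this assay.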